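A few compounds are considered here, and "the series" means these few. Any claim that something is new, unique, unknown or untested is made for them only; others in the source may bear on it.

Measured so far:
compound 1, `COc1cc(NC(C)CCCNC(=O)Nc2ccc(O)cc2)c2ncccc2c1`, gives 5200 nM in a functional assay on MCF7 cells (Homo sapiens) for inhibition, read by MTT assay, with a stated time of 72 h; a higher number here means a weaker inhibitor, a lower number a stronger inhibitor
compound 2, `COc1cc(NC(C)CCCNC(=O)NNC(=O)Nc2cccc(Cl)c2)c2ncccc2c1`, gives 220 nM in this assay

Within the data shown here, compound 2 stands at the lowest of the two numbers; its only neighbour is compound 1, and the step between them is a 24-fold lower number from compound 1 to compound 2 (1.37 log units; beyond the scatter). Compound 3, `COc1cc(NC(C)CCCNC(=O)Nc2ccc(Br)cc2)c2ncccc2c1`, differs from compound 2 by 4-bromophenyl in place of ((3-chlorophenyl)carbamoyl)amino on an amide-type nitrogen. Among the measured compounds shown here, the single measured step that bears on this is a 24-fold lower number from compound 1 to compound 2 (1.37 log units; beyond the scatter), in which the same ((3-chlorophenyl)carbamoyl)amino entered in place of a plain aromatic ring on that amide-type nitrogen. For the measured compounds named here, compound 3 reverses that kind of change, though with 4-bromophenyl rather than 4-hydroxyphenyl, and no measured pair shows how those two rings compare. A step upward in this assay is therefore expected, roughly an 11-fold higher number from compound 2 to compound 3 (1.06 log units; beyond the scatter), with wide uncertainty. Compound 3 is estimated at 2500 nM, with a range from 600 nM to 10000 nM.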

Compound 3, half-maximal inhibitory concentration: 2600 nM
Beside the measured number, compound 3's estimate is 1.0-fold (0.02 log units) below it, within the range that was stated.
By their numbers in this assay, from the lowest: compound 2; then compounds 3 and 1 (each within the scatter of the next).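

In this assay, a 12-fold higher number from compound 2 to compound 3 (1.07 log units; beyond the scatter) when 4-bromophenyl replaces ((3-chlorophenyl)carbamoyl)amino on the amide-type nitrogen, so the large gain seen with compound 2 now stands against two different plain aromatic rings, not just the hydroxy-bearing ring of compound 1. Swapping the ring substituent itself gives a 2.0-fold lower number from compound 1 to compound 3 (0.30 log units; within the scatter), so at this ring carbon the data do not separate bromo from hydroxy. No measurement shown here gives a reason for either step.

The compounds shown leave open whether the gain in compound 2 comes from the added carbamoylamino link or from the 3-chlorophenyl ring at its end, since the two enter together. They also leave open how an amine or a carboxylic acid would read on that same ring carbon in place of bromo.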